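Sulfamate series: ring amine replaced by open-chain amine

The compounds below may be only part of what the source reports. "The series", "measured", "known", "first", "only" and "open" are said of these compounds alone.

Two compounds of the series carry a number in an assay on HEK293 cells for inhibition of Steryl-sulfatase (Homo sapiens), tested at 0.1 uM; a higher number here means a stronger effect of the compound at the concentration tested, a lower number a weaker effect. Compound 1 `NS(=O)(=O)Oc1ccc2c(c1)CN(C(=O)c1cccc(N3CCC(Cc4ccccc4)CC3)c1)CC2` gives 1.4% there. Compound 2 `NS(=O)(=O)Oc1ccc2c(c1)CN(C(=O)c1ccc(N3CCCCC3)cc1)CC2` gives 11.5% in this assay, the higher of the two numbers, and its gap to compound 1 lies beyond the usual scatter. Among the measured compounds shown here, with only two compounds measured, no trend across the series can be drawn from this.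

Compound 3 `CCN(Cc1cccnc1)c1ccc(C(=O)N2CCc3ccc(OS(N)(=O)=O)cc3C2)cc1` has not yet been measured in this assay. It differs from compound 2 in one place: ethyl((pyridin-3-yl)methyl)amino in place of piperidin-1-yl on an aromatic carbon

For the measured compounds named here, no step between measured compounds shares this change, so the numbers give no guide to its direction. Both measured values sit low in this assay, and the shared core of compound 2 is otherwise untouched. The expected step is small, a number 1.5 percentage points lower from compound 2 to compound 3 (within the scatter), with no confident direction and most likely nothing beyond the scatter. Compound 3 is accordingly expected to give about 10% in this assay, within an estimated range from 0% to 28%.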

Compound 3, a percentage reported as inhibition, at one concentration (the size of the read-out at that concentration, not a potency): 35.7%
For compound 3 the middle estimate is 25.7 percentage points below the measured one; the whole stated range lies below it.
By their numbers in this assay, from the lowest: compound 1; then compound 2; then compound 3.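

In this assay, among the compounds shown here, the aromatic carbon para to a large group proves responsive to what it carries: ethyl((pyridin-3-yl)methyl)amino in place of piperidin-1-yl gives a number 24.2 percentage points higher from compound 2 to compound 3 (beyond the scatter) and provides the first readable comparison between compounds that differ in one place. The step also shows that, on this core and at this position, the ring amine is not required for the read-out, since the open-chain amine bearing a six-membered aromatic ring with one hetero atom scores higher than the piperidin-1-yl compound by more than the scatter. For the compounds shown here, no measurement bears on why the number rises, and the single step cannot separate the opening of the ring from the arrival of the ethyl or of the (pyridin-3-yl)methyl group.

The compounds shown leave open which part of the entering group carries the step: a phenylmethyl group in place of the (pyridin-3-yl)methyl group would test the ring nitrogen, and a methyl group in place of the ethyl group would test the length of that chain. Also open, going by these compounds, is whether a morpholin-4-yl ring at this position would move the number away from that of compound 2.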